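Aryl swap from compound 3 to compound 4

This account rests on a few compounds, and the source may have more. Where it says the series, first, only, none or still open, it means among the compounds named here.

Measured in a functional assay on MV4-11 cells (Homo sapiens) for antiproliferative activity, read by CCK-8 assay, with a stated time of 72 h (on this read-out higher numbers stand for weaker inhibition and lower numbers for stronger inhibition), so far:
compound 1 `Cn1cc(-c2ccccc2F)c2cc(C(=O)NCc3ccc(C(=O)Nc4ccccc4N)cc3)[nH]c2c1=O` gives 230 nM here
compound 2 `Cn1cc(-c2ccccc2)c2cc(C(=O)NCc3ccc(C(=O)Nc4ccccc4N)cc3)[nH]c2c1=O` gives 230 nM here
compound 3 `COc1ccc(C(C)(C)O)cc1-c1cn(C)c(=O)c2[nH]c(C(=O)NCc3ccc(C(=O)Nc4ccccc4N)cc3)cc12` gives 420 nM here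

Compound 3 at 420 nM lies within the scatter of both compound 1 and compound 2, so the three cannot be ranked. Compound 4 `Cc1ccccc1-c1cn(C)c(=O)c2[nH]c(C(=O)NCc3ccc(C(=O)Nc4ccccc4N)cc3)cc12` has not yet been measured. It carries 2-methylphenyl in place of 5-(1-hydroxy-1-methylethyl)-2-methoxyphenyl on an aromatic carbon. Two measured swaps at this same carbon bear on the change, a 1.8-fold higher number from compound 1 to compound 3 (0.26 log units; within the scatter) and a 1.8-fold higher number from compound 2 to compound 3 (0.26 log units; within the scatter) and both stay within the scatter. The step of no change at the digits printed from compound 1 to compound 2 (within the scatter) also stays within the scatter. Among the measured compounds shown here, with only three compounds, this is thin evidence that the group at this carbon matters little. The entering group is closer in size to the 2-fluorophenyl of compound 1 than to the leaving group, so a slight shift toward a lower number is expected. In this assay the expected step is a 1.8-fold lower number from compound 3 to compound 4 (0.24 log units; within the scatter) and nothing beyond the scatter is expected. Compound 4 is estimated at 240 nM with an expected range (120 nM to 480 nM).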

Compound 4, half-maximal inhibitory concentration: 310 nM
For compound 4 the middle estimate is 1.3-fold (0.11 log units) below the measured one, within the range that was stated.
By their numbers in this assay, from the lowest: compounds 1, 2, 4 and 3 (each within the scatter of the next).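

In this assay, the step away from the larger 5-(1-hydroxy-1-methylethyl)-2-methoxyphenyl group (a 1.4-fold lower number from compound 3 to compound 4 (0.13 log units; within the scatter)) stays within the scatter, so losing its hydrogen-bond donor and acceptors produces no readable change at this carbon. Methyl compared with hydrogen (a 1.3-fold higher number from compound 2 to compound 4 (0.13 log units; within the scatter)) and methyl compared with fluoro (a 1.3-fold higher number from compound 1 to compound 4 (0.13 log units; within the scatter)) also stay within the scatter, so these three aryl substituents cannot be told apart in this series. No supporting measurement is available to account for this flat response.

Compound 3 carries its methoxy and 1-hydroxy-1-methylethyl groups together, so the contribution of each remains unresolved. On these data alone, it also remains open whether a charged group on the aryl ring, such as a dimethylamino or carboxylic acid substituent, or a pyridine in place of the phenyl ring, would give a step beyond the scatter.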